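This account rests on a few compounds, and the source may have more. Where it says the series, first, only, none or still open, it means among the compounds named here.

Measured compounds:
compound 1 `CN(Cc1cc(C(F)(F)F)cc(C(F)(F)F)c1)C(=O)c1cnc2ccccc2c1-c1ccccc1`: 0.03 nM
compound 2 `O=C(NCc1cc(C(F)(F)F)cc(C(F)(F)F)c1)c1c(CCl)nc2ccccc2c1-c1ccccc1`: 26 nM

In an in vitro assay on UC11MG cells for binding affinity to Substance-P receptor (Homo sapiens), read by radioligand binding (on this read-out lower numbers stand for stronger inhibition and higher numbers for weaker inhibition), compound 2 stands highest of the two numbers; its nearest neighbour is compound 1, whose number is far lower, a gap well beyond the usual scatter. Within the data shown here, no step between measured compounds that differ in a single place is available here. Compound 3 `CN1CCN(Cc2nc3ccccc3c(-c3ccccc3)c2C(=O)NCc2cc(C(F)(F)F)cc(C(F)(F)F)c2)CC1` differs from compound 2 by 4-methylpiperazin-1-yl in place of chloro on a saturated chain carbon bound to an aromatic carbon. Without a comparable measured step to lean on, a moderate move toward a lower number is expected in this assay, namely a 5.2-fold lower number from compound 2 to compound 3 (0.72 log units; beyond the scatter). For compound 3 the estimated value in this assay is 5 nM, with an expected range from 0.5 nM to 50 nM.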

Compound 3, half-maximal inhibitory concentration: > 1000 nM
Compound 3: a limit, no number; the forecaster's own chance of this, stated with the estimate: 5%; middle value at least 200-fold (2.30 log units) away from the limit.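

In this assay, putting 4-methylpiperazin-1-yl in place of chloro on this saturated chain carbon gives an at least 38-fold higher number from compound 2 to compound 3 (1.58 log units; beyond the scatter), the first single-place step seen here, and it lies beyond the scatter. This shows that the position does not accept every group without a large loss. Compound 3 carries a limit of the assay and not a number, so the full size of the step stays unknown: the limit of > 1000 nM in this assay, at which 1 of the 3 values shown sits.

Going by these compounds, whether a smaller amine such as dimethylamino, or a hydroxyl or plain methyl group, would hold the number of compound 2 remains open. So does whether a longer chain carrying the 4-methylpiperazin-1-yl group would behave the same way.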